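Moving the bromine on a bis-benzylidene ketone: compound 4

The source may report more compounds than this note shows. Statements on the series, on what has been measured and on what is new or still open speak of the compounds shown alone.

Compound 1 `O=C1/C(=C/c2ccccc2)CCC/C1=C\c1cccc(Br)c1` was tested in an assay on isolated protein for inhibition of Alpha glucosidase (Homo sapiens), with stated times of 5 min and 15 min, tested at 50 uM (a higher number here means more inhibition at the concentration tested (going by the name of the read-out), a lower number less inhibition), and gives 27.2%, the lowest of the three numbers shown. Compound 2 `O=C(C1=C(O)/C(=C/c2ccc(O)cc2)CCC1)c1ccccc1` gives 34.9% in this assay, a number within the usual scatter of that of compound 1, while compound 3 `O=C(/C=C(O)/C=C/c1cc(O)ccc1O)c1ccc(O)cc1O` gives 86.6%, far beyond the scatter. The unmeasured compound 4 `O=C1/C(=C/c2ccccc2)CCC/C1=C\c1ccc(Br)cc1` differs from compound 1 in one place: 4-bromophenyl in place of 3-bromophenyl on a double-bonded chain carbon bound to a double-bonded ring carbon. Within the data shown here, no measured pair shows what such a change does here, and the bromine simply stands elsewhere on the same ring. The step of a number 2.8 percentage points higher from compound 1 to compound 4 (within the scatter) is therefore expected to stay within the scatter, in either direction. Compound 4 is estimated to give 30%, with a likely range from 12% to 48%.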

Compound 4, a percentage reported as inhibition, at one concentration (the size of the read-out at that concentration, not a potency): 29.1%
Compound 4: middle estimate off by 0.9 percentage points, on the high side, within the range that was stated.
By their numbers in this assay, from the lowest: compounds 1, 4 and 2 (each within the scatter of the next); then compound 3.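

In this assay, putting 4-bromophenyl in place of 3-bromophenyl on a double-bonded chain carbon bound to a double-bonded ring carbon gives a number 1.9 percentage points higher from compound 1 to compound 4 (within the scatter) and nothing more. Among these compounds, this assay therefore does not tell these two bromine placements apart, a point the earlier compounds could not address. No supporting measurement explains this result.

Still open is whether the bromine itself matters, as no compound shown lacks it on this otherwise unchanged core. As far as these compounds go, an amine or a carboxylic acid at this place also remains untested in these data.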